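This account rests on a few compounds, and the source may have more. Where it says the series, first, only, none or still open, it means among the compounds named here.

Measured so far in an assay on microsomes from brain for inhibition of Fatty-acid amide hydrolase 1 (Rattus norvegicus), read by fluorescence and HPLC, with a stated time of 60 min; a lower number here means a stronger inhibitor, a higher number a weaker inhibitor:
compound 1 `CCCCCCCCc1ccc(OCC(=O)Cn2nnnc2-c2cccc(S(=O)(=O)N(C)C)c2)cc1` gives 1900 nM
compound 2 `CCCCCCCCc1ccc(OCC(=O)Cn2nnnc2Cc2ccccc2)cc1` gives 320 nM

Compound 2 holds the lowest of the two numbers; its nearest neighbour, compound 1, sits higher, as the step of a 5.9-fold lower number from compound 1 to compound 2 (0.77 log units; beyond the scatter) shows, which is beyond the scatter. The next change keeps the shared core of compound 2 and again alters the group on the same ring position: compound 3 `CCCCCCCCc1ccc(OCC(=O)Cn2nnnc2C(=O)OCC)cc1` carries ethoxycarbonyl in place of benzyl on an aromatic carbon.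

Among the compounds with values here, no measured pair covers this exchange. Within the data shown here, the only step at this position, a 5.9-fold lower number from compound 1 to compound 2 (0.77 log units; beyond the scatter), is modest in size and concerns a different aromatic substituent, so it tells mainly that the group here can move this assay beyond the scatter, not in which direction the ester will go. Given that, a rise in number from compound 2 to compound 3 is expected, of size a 2.2-fold higher number from compound 2 to compound 3 (0.34 log units; beyond the scatter). Compound 3 is therefore estimated at 700 nM, with a range from 200 nM to 2500 nM.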

Compound 3, half-maximal inhibitory concentration: 940 nM
The estimate for compound 3 lay 1.3-fold (0.13 log units) below the measured number; the range from low to high includes it.
By their numbers in this assay, from the lowest: compound 2; then compound 3; then compound 1.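

In this assay, the position on the five-membered aromatic ring also tolerates ethoxycarbonyl, a group with no ring: exchanging benzyl for it gives a 2.9-fold higher number from compound 2 to compound 3 (0.47 log units; beyond the scatter), while exchanging 3-(dimethylsulfamoyl)phenyl for it gives a 2.0-fold lower number from compound 1 to compound 3 (0.31 log units; beyond the scatter). The ringless ester thus ranks in the middle, with one ring-bearing group on either side, so among these three compounds the presence of a six-membered aromatic ring in the substituent does not by itself set the order. No measurement available here accounts for this order.

From the compounds shown here alone, it remains open whether an unsubstituted phenyl at this position would rank closer to benzyl or to 3-(dimethylsulfamoyl)phenyl. Going by these compounds, the place of a carboxylic acid or a primary amide in place of ethoxycarbonyl is also open.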